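The source may report more compounds than this note shows. Statements on the series, on what has been measured and on what is new or still open speak of the compounds shown alone.

Compound 3, with the structure `COc1cc(C(c2ccc(O)c(OC)c2)[C@@H](C)[C@@H](C)CO)ccc1O`, is the weakest point of reference among the three measured compounds, and its result is a limit rather than a number: in a functional assay on HeLa cells (Homo sapiens) for cytotoxicity, read by WST assay, with a stated time of 48 h (on this read-out higher numbers stand for weaker inhibition and lower numbers for stronger inhibition), compound 3 gives > 100000 nM. This is the limit of > 100000 nM in this assay, at which 1 of the 3 values shown sits. For comparison, compound 1, with the structure `COC[C@@H](C)[C@H](C)C(c1ccc(O)c(OC)c1)c1ccc(O)c(OC)c1`, gives 58000 nM in this assay. Compound 2, with the structure `COc1cc(C(c2ccc(O)c(OC)c2)[C@@H](C)[C@H](C)CF)ccc1O`, gives 37000 nM in this assay.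

Compound 4, with the structure `COc1cc(C(c2ccc(O)c(OC)c2)[C@H](CO)C(C)C)ccc1O`, keeps every atom of compound 3 but joins them differently: 1-(hydroxymethyl)-2-methylpropyl in place of 2-(hydroxymethyl)-1-methylpropyl on a saturated chain carbon bound to two aromatic carbons. Within the data shown here, no measured step rearranges the chain in this way. The closest steps are those that introduce the hydroxymethyl group, an at least 1.7-fold higher number from compound 1 to compound 3 (0.23 log units; that floor lies within the scatter) and an at least 2.7-fold higher number from compound 2 to compound 3 (0.43 log units; beyond the scatter), both of which end at the limit. Since compound 4 still carries a hydroxymethyl group on the chain, the expected change is a step that the limit leaves unreadable from compound 3 to compound 4, that is, none beyond the scatter. Compound 4 is therefore estimated at 110000 nM in this assay, with a likely range from 45000 nM to 300000 nM, and the result may again be reported only as a limit.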

Compound 4, half-maximal inhibitory concentration: > 100000 nM
Compound 4 ended at the assay's limit; the forecaster's own chance of this, stated with the estimate: 60%; the middle value lies beyond the limit too.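

Rearranging the chain to 1-(hydroxymethyl)-2-methylpropyl, on a saturated chain carbon bound to two aromatic carbons, gives a second compound that reads only as a limit, not a number: the limit of > 100000 nM in this assay, at which 2 of the 4 values shown sit. Compound 3 and compound 4 are both limits, so the step between them cannot be read, and the change in chain shape has no measurable size here. Two steps can be read, an at least 2.7-fold higher number from compound 2 to compound 4 (0.43 log units; beyond the scatter) and an at least 1.7-fold higher number from compound 1 to compound 4 (0.23 log units; that floor lies within the scatter), and only the first of them clears the scatter.

The compounds shown leave open how far past the limit compound 3 and compound 4 truly lie. They also leave open whether this rearranged chain would give a readable value if it carried an amine or a fluoro group in place of the hydroxyl.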